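Side-chain change on a carboxylic acid carrier

This account rests on a few compounds, and the source may have more. Where it says the series, first, only, none or still open, it means among the compounds named here.

Compound 1, `CSCC[C@H](NC(=O)CN(c1nc(Cl)nc2[nH]cnc12)C1CC1)C(=O)OCc1ccccc1`, in a functional assay on the whole organism (Tail, strain ICR) with Mus musculus as the target, in the tail flick test, with a stated time of 30 min, at a dose of 25 umol/kg by the oral route (a higher number here means a stronger effect of the compound at the dose given, a lower number a weaker effect), gives 22.2%.
Compound 2, `CC[C@H](C)[C@H](NC(=O)CN(c1nc(Cl)nc2[nH]cnc12)C1CC1)C(=O)OCc1ccccc1`, in this assay gives 41.4%.
Compound 3, `CSCC[C@H](NC(=O)CN(c1nc(Cl)nc2[nH]cnc12)C1CC1)C(=O)O`, in this assay gives 20.4%.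

Compound 3 sits together with compound 1 within the scatter, and compound 2 stands above both beyond it. The step from compound 1 to compound 3 shows that the ester and the free acid give the same read-out: a number 1.8 percentage points lower from compound 1 to compound 3 (within the scatter). Among the compounds with values here, the one step that touches the side chain is a number 19.2 percentage points higher from compound 1 to compound 2 (beyond the scatter), a modest gain.

Compound 4, `NCCCC[C@H](NC(=O)CN(c1nc(Cl)nc2[nH]cnc12)C1CC1)C(=O)O`, differs from compound 3 in the side chain only: 2-aminoethyl in place of methylsulfanyl on a saturated chain carbon, three bonds along the chain from an amide-type nitrogen and a carbonyl carbon. Within the data shown here, the only measured precedent for a side-chain change is the step from compound 1 to compound 2, and that replaced the same group by a different one, so it gives direction only loosely. The acid position itself changes nothing beyond the scatter in this assay. Compound 4 is therefore expected to stay near compound 3, with a step of a number 5.6 percentage points higher from compound 3 to compound 4 (within the scatter), and its read-out in this assay is estimated at 26%, between 10% and 45%.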

Compound 4, a percentage reported as activity, at one dose (the size of the read-out at that dose, not a potency): 31.2%
Compound 4: the middle estimate sits 5.2 percentage points below what was measured; the range from low to high includes it.
By their numbers in this assay, from the lowest: compounds 3, 1 and 4 (each within the scatter of the next, the first and the last beyond it); then compound 2.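

In this assay, the side chain also counts on the free acid: 2-aminoethyl in place of methylsulfanyl, on a saturated chain carbon, three bonds along the chain from an amide-type nitrogen and a carbonyl carbon, gives (a number 10.8 percentage points higher from compound 3 to compound 4 (beyond the scatter)). Within the data shown here, the earlier side-chain step beyond the scatter (a number 19.2 percentage points higher from compound 1 to compound 2 (beyond the scatter)) was on a benzyl ester, so this is the first sign that the position answers on a carboxylic acid too, here with a chain ending in an amine, although the step is modest. Nothing available here explains this step.

On these data alone, it remains open whether the amine or the chain itself drives the change, which a 4-hydroxybutyl or plain butyl chain on the same acid could test. A benzyl ester carrying the 4-aminobutyl chain would show whether the step holds on the ester as well.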